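This account rests on a few compounds, and the source may have more. Where it says the series, first, only, none or still open, it means among the compounds named here.

The measured compounds, all read in a functional assay on MCF7 cells (Homo sapiens) for antiproliferative activity, read by MTT assay, with a stated time of 72 h; a higher number here means a weaker inhibitor, a lower number a stronger inhibitor:

compound 1, `COc1cc(-n2cnc3ccc(-c4ccc([N+](=O)[O-])cc4)cc32)cc(OC)c1OC`: 740 nM
compound 2, `COc1cc(-n2cnc3ccc(-c4ccc(C(F)(F)F)cc4)cc32)cc(OC)c1OC`: 760 nM
compound 3, `COc1cc(-n2cnc3ccc(-c4cccc(C)c4C)cc32)cc(OC)c1OC`: 2150 nM

The three share one core and differ only in the aryl group attached to it. Compound 1 and compound 2 lie within the scatter of each other, a 1.0-fold higher number from compound 1 to compound 2 (0.01 log units; within the scatter). Compound 3 stands apart with the highest number of the three: a 2.9-fold higher number from compound 1 to compound 3 (0.46 log units; beyond the scatter) and a 2.8-fold higher number from compound 2 to compound 3 (0.45 log units; beyond the scatter), both beyond the scatter and both modest in size.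

Compound 4, `COc1cc(-n2cnc3ccc(-c4cccc([N+](=O)[O-])c4)cc32)cc(OC)c1OC`, has not yet been measured in this assay. Its change from compound 3 is 3-nitrophenyl in place of 2,3-dimethylphenyl on an aromatic carbon. The two steps that bear on it are the ones into compound 3, where a 2,3-dimethylphenyl took the place of a 4-substituted phenyl and the number rose by a similar, modest amount each time. Going by the values given here, compound 4 reverses that kind of change, again toward a nitrophenyl, though the nitro group now sits at a different place on the ring than in compound 1, and no measured step covers that shift. A modest step downward is therefore expected, perhaps somewhat smaller than the measured ones. Compound 4 is estimated at 950 nM, with a range of 450 nM to 2100 nM. That estimate means an expected 2.3-fold lower number from compound 3 to compound 4 (0.35 log units; beyond the scatter).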

Compound 4, half-maximal inhibitory concentration: 4560 nM
Compound 4: middle estimate off by 4.8-fold (0.68 log units), on the low side; measured number above the stated range.
By their numbers in this assay, from the lowest: compounds 1 and 2 (each within the scatter of the next); then compound 3; then compound 4.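

In this assay, the new result shows that the place of the nitro group on the phenyl ring matters, with a 6.2-fold higher number from compound 1 to compound 4 (0.79 log units; beyond the scatter). The earlier compounds shown here carried nitro only as 4-nitrophenyl, and they could not offer this contrast. A nitro group therefore does not by itself go with a low number here: 3-nitrophenyl gives a 6.0-fold higher number from compound 2 to compound 4 (0.78 log units; beyond the scatter) against 4-(trifluoromethyl)phenyl, and it even falls behind the 2,3-dimethylphenyl group, with a 2.1-fold higher number from compound 3 to compound 4 (0.33 log units; beyond the scatter), so that among these four the two 4-substituted phenyl groups hold the lowest numbers and no compound shown goes against that. Nothing measured here explains why the shift of the nitro group has this effect.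

The compounds shown leave open whether trifluoromethyl would respond in the same way if it were moved as the nitro group was, and whether the unsubstituted phenyl group would sit nearer to compound 1 or to compound 4. They also leave open what an amine or a carboxylic acid would do in place of the nitro group, at either of the two places on the phenyl ring.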